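The source may report more compounds than this note shows. Statements on the series, on what has been measured and on what is new or still open speak of the compounds shown alone.

Measured so far:
Compound 1 `CC(C)(C)n1ncc(OCc2nnc(-c3cc(F)c(F)cc3F)o2)c(Cl)c1=O` — 75.7 ug/mL
Compound 2 `CC(C)(C)n1ncc(OCc2nnc(-c3cccs3)o2)c(Cl)c1=O` — > 300 ug/mL
Compound 3 `CC(C)(C)n1ncc(OCc2nnc(-c3ccc(Cl)cc3)o2)c(Cl)c1=O` — 1.9 ug/mL

In a functional assay on the whole organism for inhibition, with Mythimna separata as the target, with a stated time of 5 days (on this read-out lower numbers stand for an effect already at smaller amounts and higher numbers for an effect only at larger amounts of compound), compound 3 gives 1.9 ug/mL, the lowest number among the measured compounds. Compound 1 gives 75.7 ug/mL, a result that is a 40-fold lower number from compound 1 to compound 3 (1.60 log units; beyond the scatter). For compound 2 this assay reports only a limit, > 300 ug/mL. Compound 4 `CC(C)(C)n1ncc(OCc2nnc(-c3ccc(F)cc3)o2)c(Cl)c1=O` differs from compound 3 by fluoro in place of chloro on an aromatic carbon. Within the data shown here, no measured step exchanges one halogen for another on that ring; the measured steps of a 40-fold lower number from compound 1 to compound 3 (1.60 log units; beyond the scatter) and an at least 150-fold lower number from compound 2 to compound 3 (2.19 log units; beyond the scatter) replace the whole ring and show that this part of the molecule matters greatly, but they do not say how much a single halogen swap counts. A modest rise in the number is expected, giving for compound 4 an estimate of 4.5 ug/mL (range 1.5 ug/mL to 15 ug/mL), meaning an expected step of a 2.4-fold higher number from compound 3 to compound 4 (0.37 log units; beyond the scatter).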

Compound 4, half-maximal effective concentration: 5.2 ug/mL
Compound 4: middle estimate off by 1.2-fold (0.06 log units), on the low side, within the range that was stated.
By their numbers in this assay, from the lowest: compound 3; then compound 4; then compound 1. At a limit, above all of these: compound 2.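

Exchanging only the halogen on the six-membered aromatic ring, para to a large group, gives a modest but real change: a 2.7-fold higher number from compound 3 to compound 4 (0.44 log units; beyond the scatter). Replacing the whole ring gives much larger steps, so the choice of ring counts for more here than the choice between chloro and fluoro: an at least 57-fold lower number from compound 2 to compound 4 (1.76 log units; beyond the scatter) and a 15-fold lower number from compound 1 to compound 4 (1.16 log units; beyond the scatter). Compound 2 enters that comparison only as a limit: the limit of > 300 ug/mL in this assay, at which 1 of the 4 values shown sits.

As far as these compounds go, whether bromo, methyl, methoxy or an amine in the same place would give a number like that of compound 3 remains open. The compounds shown also do not explain why chloro gives the lower number.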